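This account rests on a few compounds, and the source may have more. Where it says the series, first, only, none or still open, it means among the compounds named here.

In an ADME assay on L929 cells (Mus musculus) for cytotoxicity, read by resazurin assay, with a stated time of 72 h (a higher number here means a weaker inhibitor, a lower number a stronger inhibitor), compound 1 `O=C(/C=C/c1ccc2c(c1)B(O)OC2)c1ccc(F)cc1` gives > 10 ug/mL, which is a limit of the assay and not a number. Compound 2 `Cc1ccc(C(=O)/C=C/c2ccc3c(c2)B(O)OC3)cc1` gives > 10 ug/mL, again a limit and not a number. The two compounds therefore share one reading, (the limit of > 10 ug/mL in this assay, at which 2 of the 2 values shown sit). Among the compounds with values here, replacing fluoro with methyl on an aromatic carbon is the only measured change, and it is a step that the two limits leave unreadable from compound 1 to compound 2, so it offers no size to carry forward.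

Compound 3 `Cn1cccc1C(=O)/C=C/c1ccc2c(c1)B(O)OC2` has not yet been measured. It carries 1-methyl-1H-pyrrol-2-yl in place of 4-methylphenyl on a carbonyl carbon. Within the data shown here, no measured step makes this change, so neither direction is favoured, and no shift beyond the usual scatter can be predicted in this assay. The expectation rests on compound 2, which reads > 10 ug/mL, a limit. The expected step is a step that the limit leaves unreadable from compound 2 to compound 3, an estimate with no clear direction. The estimated value for compound 3 is 20 ug/mL, with an expected range of 7 ug/mL to 50 ug/mL. The assay may well report only a limit again.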

Compound 3, half-maximal inhibitory concentration: > 10 ug/mL
Compound 3 ended at the assay's limit (the forecaster's own chance of this, stated with the estimate: 75%); the middle value is on the limit's open side.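

Compound 3 gives > 10 ug/mL in this assay, which is a limit of the assay and not a number. Within the data shown here, no step among compound 1, compound 2 and compound 3 can be read, as all three share one reading: the limit of > 10 ug/mL in this assay, at which 3 of the 3 values shown sit. The compounds shown leave open how far each lies from that limit, and whether exchanging the 4-fluorophenyl, 4-methylphenyl and 1-methyl-1H-pyrrol-2-yl groups changes the reading at all.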